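Branching the ketone chain: propyl to isopropyl

This account rests on a few compounds, and the source may have more. Where it says the series, first, only, none or still open, it means among the compounds named here.

Compound 1 `Cc1c(OCCCCOc2ccccc2C(=O)O)ccc(C(=O)CC2CCCC2)c1O` belongs to the same series, but in an assay on HEK293 cells for positive allosteric modulation of metabotropic glutamate receptor 3 (Rattus norvegicus), read by thallium flux, with a stated time of 2.5 min (on this read-out higher numbers stand for an effect only at larger amounts of compound and lower numbers for an effect already at smaller amounts), compound 1 gives "not determined" (no result reported), so no number is available for it. In this assay, for the measured compounds named here, compound 2 `CCCC(=O)c1ccc(OCCCCOc2ccc(F)c(C(=O)O)c2)c(C)c1O` gives 438 nM, the only number available here. Compound 3 `Cc1c(OCCCCOc2ccc(F)c(C(=O)O)c2)ccc(C(=O)C(C)C)c1O` differs from compound 2 by isopropyl in place of propyl on a carbonyl carbon. Going by the values given here, no measured pair shows what such a change does in this assay, so a shift of a 1.3-fold higher number from compound 2 to compound 3 (0.10 log units; within the scatter) is expected, a step that stays within the usual scatter, leaning slightly toward weaker. Compound 3 is therefore estimated at 550 nM, with a likely range from 200 nM to 1500 nM.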

Compound 3, half-maximal effective concentration: > 10000 nM
Compound 3 ended at the assay's limit; the forecaster's own chance of this, stated with the estimate: 10%; middle value at least 18-fold (1.25 log units) from the limit.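

In this assay, this carbonyl carbon proves sensitive to the shape of its chain: replacing propyl with isopropyl, which has the same three carbons, gives an at least 22-fold higher number from compound 2 to compound 3 (1.35 log units; beyond the scatter). At this position, then, how the carbons are joined matters and not only how many there are. The value for compound 3 is a limit of the assay and not a number: the limit of > 10000 nM in this assay, at which 1 of the 3 values shown sits.

The compounds shown leave open whether an unbranched longer chain such as butyl, or a small ring such as cyclopropyl, on this carbonyl carbon would keep the effect seen with propyl.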